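A few compounds are considered here, and "the series" means these few. Any claim that something is new, unique, unknown or untested is made for them only; others in the source may bear on it.

Compound 1 `O=S(=O)(Nc1ccc2oc(-c3ccccc3)nc2c1)c1cccc(C(F)(F)F)c1` and compound 2 `O=S(=O)(Nc1ccc2oc(-c3ccccc3)nc2c1)c1ccccc1F` share one core, each carrying a different aryl group on the sulfonyl sulfur. In an assay on isolated protein for inhibition of malate dehydrogenase, mitochondrial (Sus scrofa), with stated times of 45 min and 30 min (on this read-out lower numbers stand for stronger inhibition and higher numbers for weaker inhibition), compound 1 reaches only the limit of the measurement, > 63000 nM. Compound 2 likewise reaches only the limit in this assay, > 63000 nM. Both values therefore sit together at the edge of what can be read, (the limit of > 63000 nM in this assay, at which 2 of the 2 values shown sit), so compound 2 stands level with its single companion. Compound 3 `O=S(=O)(Nc1ccc2oc(-c3ccccc3)nc2c1)c1cccc(Cl)c1` differs by 3-chlorophenyl in place of 2-fluorophenyl on a sulfonyl sulfur. Among the compounds with values here, with no measured step available, the expected step is a step that the limit leaves unreadable from compound 2 to compound 3, none beyond the scatter. Compound 3 is accordingly estimated at 100000 nM, ranging from 30000 nM to 300000 nM.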

Compound 3, half-maximal inhibitory concentration: > 63000 nM
Compound 3 gave a limit, no number; the forecaster's own chance of this, stated with the estimate: 85%; the middle value does not contradict the limit.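

Compound 3, like compound 1 and compound 2, gives only a limit in this assay, so no step between these compounds can be read: the limit of > 63000 nM in this assay, at which 3 of the 3 values shown sit.

From the compounds shown here alone, how strongly each of the three inhibits, and whether their different aryl groups on the sulfonyl sulfur change that, stays open.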